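The source may hold more compounds than are shown below. What is called first, only, known or untested is meant among the compounds shown, and "the series" means these compounds.

In a functional assay on MCF7 cells (Homo sapiens) for antiproliferative activity, read by sulforhodamine B assay, with a stated time of 48 h (a higher number here means a weaker inhibitor, a lower number a stronger inhibitor), the measured compounds are:
Compound 1 `Cc1ccc(OS(=O)(=O)c2ccc(N3CCN(C)C3=O)cc2)c(C)c1`: 2500 nM
Compound 2 `CCN1CCN(c2ccc(S(=O)(=O)Oc3ccccc3OC)cc2)C1=O`: > 100000 nM
Compound 3 `CCCN1CCN(c2ccc(S(=O)(=O)Oc3ccc(C)cc3C)cc2)C1=O`: 1500 nM

Among the compounds with values here, compound 3 stands level with compound 1, the only other compound with a number: a 1.7-fold lower number from compound 1 to compound 3 (0.22 log units; within the scatter). Compound 2 is recorded only as a limit, (the limit of > 100000 nM in this assay, at which 1 of the 3 values shown sits).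

Compound 4 `CCCN1CCN(c2ccc(S(=O)(=O)Oc3cccc([N+](=O)[O-])c3)cc2)C1=O` carries 3-nitrophenyl in place of 2,4-dimethylphenyl on the oxygen bound to the sulfonyl sulfur (3-nitrophenyl in place of 2,4-dimethylphenyl on an oxygen). Within the data shown here, the one measured step, a 1.7-fold lower number from compound 1 to compound 3 (0.22 log units; within the scatter), lies on the chain and leaves that oxygen's group unchanged, so it offers little guidance. Compound 2 differs from compound 3 at that oxygen and on the chain. Compound 2 reads > 100000 nM, which is a limit. A higher number is therefore expected, though only loosely. The expected change is a 5.3-fold higher number from compound 3 to compound 4 (0.73 log units; beyond the scatter). For compound 4 the estimated value is 8000 nM, with an expected range from 1500 nM to 60000 nM.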

Compound 4, half-maximal inhibitory concentration: 19000 nM
Estimate against measurement, compound 4: 2.4-fold (0.38 log units) below; measured number inside the range.
By their numbers in this assay, from the lowest: compounds 3 and 1 (each within the scatter of the next); then compound 4. At a limit, above all of these: compound 2.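

On the oxygen bound to the sulfonyl sulfur, the group proves to matter in this assay: 3-nitrophenyl in place of 2,4-dimethylphenyl gives a 13-fold higher number from compound 3 to compound 4 (1.10 log units; beyond the scatter), with the propyl chain and the core unchanged. Within the data shown here, the only earlier step lay on the chain and stayed within the scatter, so this is the first readable change at this oxygen. No measured property accounts for it. As far as these compounds go, it remains open whether the change follows from gaining the nitro group or from losing the two methyl groups. From the compounds shown here alone, how plain phenyl or an aminophenyl group would read on that oxygen also remains open.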